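Working notes: 2-chlorobenzyl to 3-chlorobenzyl swap

This account rests on a few compounds, and the source may have more. Where it says the series, first, only, none or still open, it means among the compounds named here.

Values in a functional assay on SW 1116 cells (Homo sapiens) for antiproliferative activity, read by MTT assay, with a stated time of 24 h (a lower number here means a stronger inhibitor, a higher number a weaker inhibitor), are as follows
- compound 1 `c1ccc(CSc2nnc(-c3ccc4c(c3)OCCO4)n2-c2ccccc2)cc1` gives 7930 nM
- compound 2 `O=[N+]([O-])c1cccc(CSc2nnc(-c3ccc4c(c3)OCCO4)n2-c2ccccc2)c1` gives 7590 nM
- compound 3 `Clc1ccccc1CSc1nnc(-c2ccc3c(c2)OCCO3)n1-c1ccccc1` gives 9670 nM

Compound 3 stands within the scatter of the other two, as a 1.2-fold higher number from compound 1 to compound 3 (0.09 log units; within the scatter) (chloro in place of hydrogen) and a 1.3-fold higher number from compound 2 to compound 3 (0.11 log units; within the scatter) both show. Compound 4 `Clc1cccc(CSc2nnc(-c3ccc4c(c3)OCCO4)n2-c2ccccc2)c1` has 3-chlorophenyl in place of 2-chlorophenyl on a saturated chain carbon bound to a sulfur. The nearest evidence is these same steps, together with a 1.0-fold lower number from compound 1 to compound 2 (0.02 log units; within the scatter) (nitro in place of hydrogen). All three are small, so changes on this phenyl have so far moved nothing beyond the scatter. None of them tests this exact exchange of chlorine positions, so the evidence is indirect. No step beyond the scatter is therefore expected in this assay and no direction can be favoured. The expected change is a 1.2-fold lower number from compound 3 to compound 4 (0.07 log units; within the scatter) and no more. Compound 4 is estimated at 8300 nM with an expected range from 4500 nM to 15000 nM for now.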

Compound 4, half-maximal inhibitory concentration: 10600 nM
Compound 4: middle estimate off by 1.3-fold (0.11 log units), on the low side, within the range that was stated.
By their numbers in this assay, from the lowest: compounds 2, 1, 3 and 4 (each within the scatter of the next).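

In this assay, among the compounds shown here, the chlorine exchange itself now has a direct reading: a 1.1-fold higher number from compound 3 to compound 4 (0.04 log units; within the scatter) shows that 3-chlorophenyl in place of 2-chlorophenyl on a saturated chain carbon bound to a sulfur leaves the number within the scatter, which the earlier steps could only suggest indirectly. The comparisons of the new compound with the other two agree, as a 1.4-fold higher number from compound 2 to compound 4 (0.15 log units; within the scatter) and a 1.3-fold higher number from compound 1 to compound 4 (0.13 log units; within the scatter) both show, so the unsubstituted phenyl, 3-nitrophenyl, 2-chlorophenyl and 3-chlorophenyl cannot be told apart in this series. No supporting measurement bears on this flat result.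

From the compounds shown here alone, it remains open whether any change on this phenyl can move the number beyond the scatter, for instance an amine or a carboxylic acid in place of the chlorine. A longer chain between the sulfur and the phenyl is equally untested by the compounds shown here.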